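Carbamate ester enlargement on an inactive thiazolidinedione analogue

This account rests on a few compounds, and the source may have more. Where it says the series, first, only, none or still open, it means among the compounds named here.

Compound 1 `Cc1c(Oc2ccc(/C=C3\SC(=O)NC3=O)cc2)ncnc1OC1CCN(C(=O)OCC(C)C)CC1` and compound 2 `CCOC(=O)N1CCC(Oc2cc(Oc3ccc(/C=C4\SC(=O)NC4=O)cc3)ncn2)CC1` both give numbers in a functional assay on CHO-K1 cells for agonist activity at Glucose-dependent insulinotropic receptor (Homo sapiens), read by cAMP accumulation and immunoassay, with a stated time of 1 h; a higher number here means that more compound is needed for the effect, a lower number that less compound is needed: compound 1 gives 75.1 nM, compound 2 gives 790 nM. Compound 3 `CCOC(=O)N1CCC(Oc2ncnc(Oc3cccc(/C=C4\SC(=O)NC4=O)c3)c2C)CC1` shares the carbamate-bearing piperidine and the thiazolidinedione end of the series, but in this assay compound 3 is reported as "not active" (no number reported), so no single number fixes where it stands relative to the others. Compound 4 `Cc1c(Oc2cccc(/C=C3\SC(=O)NC3=O)c2)ncnc1OC1CCN(C(=O)OCc2ccccc2)CC1` keeps the whole frame of compound 3 and differs only in the carbamate ester: phenyl in place of methyl on a saturated chain carbon bound to an oxygen next to a carbonyl group. Among the measured compounds shown here, with compound 3 giving no number, no measured step sets the size of this change; the expectation is for little movement beyond the scatter, and compound 4 is estimated at 8000 nM in this assay, within a range of 1500 nM to 40000 nM, with a real chance that again only a limit is reported.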

Compound 4, half-maximal effective concentration: 106 nM
Compound 4: middle estimate off by 75-fold (1.88 log units), on the high side; measured number outside the range, below it.
By their numbers in this assay, from the lowest: compounds 1 and 4 (each within the scatter of the next); then compound 2.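

Among the compounds shown here, compound 3 carries no number, and no step from it to compound 4 can be read. The compounds shown leave open how far ethoxycarbonyl to benzyloxycarbonyl alone moves the value. No evidence bears on this result.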